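This account rests on a few compounds, and the source may have more. Where it says the series, first, only, none or still open, it means among the compounds named here.

Among the measured compounds shown here, compound 2 `CCCCCc1ccc(-c2cn(C[C@H](O)[C@H]3OC(=O)C(OCc4ccccc4)=C3OCc3ccccc3)nn2)cc1` gives 9890 nM in a functional assay on CFPAC-1 cells (Homo sapiens) for antiproliferative activity, read by MTT assay, with a stated time of 72 h (on this read-out lower numbers stand for stronger inhibition and higher numbers for weaker inhibition), the only number among the three values shown. Compound 1 `O=C1O/C(=C\Cn2cc(-c3ccc(Br)cc3)nn2)C(OCc2ccccc2)=C1OCc1ccccc1` gives only a limit in this assay, > 100000 nM. Compound 3 `COc1ccccc1-c1cn(C/C=C2\OC(=O)C(OCc3ccccc3)=C2OCc2ccccc2)nn1` likewise gives only a limit, > 100000 nM. The step that the two limits leave unreadable from compound 1 to compound 3 is therefore unreadable, since (the limit of > 100000 nM in this assay, at which 2 of the 3 values shown sit). Compound 4 `Cc1ccc(S(=O)(=O)NCc2cn(C[C@H](O)[C@H]3OC(=O)C(OCc4ccccc4)=C3OCc3ccccc3)nn2)cc1` differs from compound 2 by (((4-methylphenyl)sulfonyl)amino)methyl in place of 4-pentylphenyl on an aromatic carbon. No measured step covers this change, and the one step shown has no readable size, so the expectation rests on compound 2 alone. A weakening step beyond the scatter is expected, a 3.5-fold higher number from compound 2 to compound 4 (0.55 log units; beyond the scatter), with a real chance that this assay returns only a limit. Compound 4 is estimated at 35000 nM, between 9000 nM and 100000 nM.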

Compound 4, half-maximal inhibitory concentration: 68000 nM
Estimate against measurement, compound 4: 1.9-fold (0.29 log units) below; the range from low to high includes it.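

In this assay, replacing 4-pentylphenyl with (((4-methylphenyl)sulfonyl)amino)methyl on the aromatic carbon of the triazole-type ring gives a 6.9-fold higher number from compound 2 to compound 4 (0.84 log units; beyond the scatter). Among the compounds shown here, this is the first readable step in the set, and it shows that this position responds to the change. Compound 4 still returns a number and not a limit, so 4-pentylphenyl is not needed for a measurable value here, unlike the limit reached by other compounds: the limit of > 100000 nM in this assay, at which 2 of the 4 values shown sit.

The compounds shown leave open whether the step follows the loss of the pentyl chain or the arrival of the sulfonyl and amino link. A plain phenyl on the same carbon would separate the two.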